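A few compounds are considered here, and "the series" means these few. Any claim that something is new, unique, unknown or untested is made for them only; others in the source may bear on it.

Measured so far:
compound 1, `CCCCCCCCC(O)CNCCO`: 2.14
compound 2, `CCCCCCCCCCCCC(O)CNCCO`: 4.69

In a physicochemical assay for lipophilicity (on this read-out lower numbers stand for lower lipophilicity and higher numbers for higher lipophilicity), compound 1 gives 2.14, the lower of the two numbers recorded; compound 2 gives 4.69. For the measured compounds named here, the single measured step, a number 2.55 log units higher from compound 1 to compound 2 (beyond the scatter), concerns a longer saturated chain and nothing else.

Compound 3, `CCCCCCCCCCNCCO`, has not yet been measured. It differs from compound 1 by hydrogen in place of hydroxy on a saturated chain carbon bound to two saturated chain carbons. Going by the values given here, no measured pair touches the hydroxy group, so the step from compound 1 to compound 2 does not bear directly on this change; it only sets the scale on which the series moves, and it was large. Loss of one hydrogen-bond donor and one hydrogen-bond acceptor with the chain kept intact is expected to move this assay upward, beyond the scatter but by less than the chain extension did. Compound 3 is therefore estimated at 3.3, within 2.6 to 4. The expected step is a number 1.16 log units higher from compound 1 to compound 3 (beyond the scatter).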

Compound 3, partition coefficient: 3.09
Compound 3: middle estimate off by 0.21 log units, on the high side; measured number inside the range.
By their numbers in this assay, from the lowest: compound 1; then compound 3; then compound 2.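

In this assay, for the compounds shown here, hydrogen in place of hydroxy on a saturated chain carbon bound to two saturated chain carbons gives a number 0.95 log units higher from compound 1 to compound 3 (beyond the scatter) as the first reading on this position, which the chain pair could not supply. Going by these compounds alone, this step is modest, while the only other step on record, a number 2.55 log units higher from compound 1 to compound 2 (beyond the scatter) for butyl in place of hydrogen on a saturated chain carbon, is large, so the series now has one reading for each kind of change. Nothing measured accounts for the size of the step at this position.

Going by these compounds, whether methoxy, fluorine or a carboxylic acid in place of hydroxy on this carbon would land near compound 1 or near compound 3 stays open. On these data alone, it also stays open whether the same change on the longer chain of compound 2 gives a step of similar size.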